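The compounds below may be only part of what the source reports. "The series", "measured", "known", "first", "only" and "open" are said of these compounds alone.

Compound 1, `COc1ccc(OCC(=O)N2CCC3(CC2)CN(Cc2ccc(OCC(C)C)cc2Cl)C3)cc1`, gives 20 nM in an assay on HEK293 cells for antagonist activity at growth hormone secretagogue receptor type 1 (Homo sapiens); on this read-out higher numbers stand for weaker inhibition and lower numbers for stronger inhibition.
Compound 2, `COc1ccc(OCC(=O)N2CCC3(CC2)CN(Cc2ccc(-n4cccn4)cc2)C3)cc1`, gives 152 nM in this assay.
Compound 3, `COc1ccc(OCC(=O)N2CCC3(CC2)CN(Cc2ccc(-n4nccn4)cc2Cl)C3)cc1`, gives 11 nM in this assay.

Compound 1 sits second highest of the three numbers. Its closest neighbour is compound 3, where the change from compound 1 to compound 3 was a 1.8-fold lower number from compound 1 to compound 3 (0.26 log units; within the scatter), a gap that is within the scatter; compound 2 stands well beyond the scatter on the weaker side. Compound 4, `COc1ccc(OCC(=O)N2CCC3(CC2)CN(Cc2ccc(OCC(C)C)cc2Cl)C3)cn1`, has not yet been measured. It differs from compound 1 in one place: 6-methoxypyridin-3-yl in place of 4-methoxyphenyl on an oxygen on a saturated carbon. Within the data shown here, no measured step touches this part of the molecule; the only step in hand, from compound 1 to compound 3, alters a group on the other aromatic ring, and so says nothing direct about swapping one ring atom in the methoxyphenoxy arm for nitrogen. With no guide either way, the expected step from compound 1 to compound 4 is a 1.3-fold higher number from compound 1 to compound 4 (0.10 log units; within the scatter), not beyond the scatter. Compound 4 is therefore estimated at 25 nM, with a range from 8 nM to 80 nM.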

Compound 4, inhibition constant: 17 nM
For compound 4 the middle estimate is 1.5-fold (0.17 log units) above the measured one; the range from low to high includes it.
By their numbers in this assay, from the lowest: compounds 3, 4 and 1 (each within the scatter of the next); then compound 2.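

Putting 6-methoxypyridin-3-yl in place of 4-methoxyphenyl on the oxygen gives a 1.2-fold lower number from compound 1 to compound 4 (0.07 log units; within the scatter) in this assay, so the two compounds cannot be told apart on this read-out. Among these compounds, this is the first measured change in this arm of the molecule, since the earlier step touched only the other aromatic ring, and it shows that here a ring nitrogen can stand in for a ring carbon, taking the count of hydrogen-bond acceptors in the group from 1 to 2, with no change beyond the scatter. No measurement available here explains this outcome.

Still open, as far as these compounds go, is whether a pyrimidine ring, or a carboxylic acid in place of the methoxy group, would fare as well at this position. Also open, from the compounds shown here alone, is whether the same swap gives a similar result alongside the 2H-1,2,3-triazol-2-yl group of compound 3.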